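Cyano-substituted bicyclic series: step from compound 3 to compound 4

This account rests on a few compounds, and the source may have more. Where it says the series, first, only, none or still open, it means among the compounds named here.

Measured compounds and values:
compound 1 `N#CC1=C(NCC(=O)N2CCOCC2)N(c2ccccc2)C(=O)N2CCCCC(N3CCCC3)C12` 69.8%
compound 2 `N#CC1=C(NCN2CCCC2)N(c2ccccc2)C(=O)N2CCCCC(N3CCCC3)C12` 26.6%
compound 3 `N#CC1=C(/N=C/Nc2ccc([N+](=O)[O-])cc2)N(c2ccccc2)C(=O)N2CCCCC(N3CCCC3)C12` 41.5%

In a functional assay on the whole organism (strain albino) for inhibition, with Rattus norvegicus as the target, read by paw edema, with stated times of 1 h and 2 h, at a dose of 20 mmol/kg by the intraperitoneal route (on this read-out higher numbers stand for more inhibition at the one dose given (going by the name of the read-out) and lower numbers for less inhibition), compound 1 gives 69.8%, the highest of the three. Compound 3 gives 41.5% and stands second highest; compound 2 gives 26.6%, the lowest. Both steps from compound 1 lie beyond the scatter: a number 43.2 percentage points lower from compound 1 to compound 2 (beyond the scatter) and a number 28.3 percentage points lower from compound 1 to compound 3 (beyond the scatter). Between the two lower compounds, a number 14.9 percentage points higher from compound 2 to compound 3 (beyond the scatter).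

Compound 4 `N#CC1=C(NCN2CCCCC2)N(c2ccccc2)C(=O)N2CCCCC(N3CCCC3)C12` has not yet been measured. The change from compound 3 is a group of 8 heavy atoms (6 carbon, 2 nitrogen; one six-membered non-aromatic ring with 1 hetero atom) in place of a group of 12 heavy atoms (7 carbon, 3 nitrogen, 2 oxygen; one six-membered aromatic ring of carbon only), on a double-bonded ring carbon. Going by the values given here, the closest measured step is the one from compound 2 to compound 3, since compound 2 carries a ((pyrrolidin-1-yl)methyl)amino group on the same double-bonded ring carbon and compound 4 carries the six-membered homologue of it. Reversing that modest step suggests a drop from compound 3 toward the value of compound 2, though a single ring-size change on the saturated ring gives no measured precedent of its own.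

For compound 4 the expected step is a number 11.5 percentage points lower from compound 3 to compound 4 (beyond the scatter), downward and beyond the scatter. Compound 4 is therefore estimated at 30%, with a range from 15% to 50%.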

Compound 4, a percentage reported as inhibition, in the whole organism at one dose (the size of the read-out at that dose, not a potency): 36.9%
The estimate for compound 4 lay 6.9 percentage points below the measured number; measured number inside the range.
By their numbers in this assay, from the lowest: compound 2; then compounds 4 and 3 (each within the scatter of the next); then compound 1.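

In this assay the size of the saturated ring on the chain now has a reading of its own: with piperidin-1-yl in place of pyrrolidin-1-yl on the saturated chain carbon bound to an amine nitrogen, the result is a number 10.3 percentage points higher from compound 2 to compound 4 (beyond the scatter), so this ring is not interchangeable at this position, although the step is a modest one. The ((piperidin-1-yl)methyl)amino group and the larger group of compound 3, with its six-membered aromatic ring of carbon only, cannot be told apart on the double-bonded ring carbon (a number 4.6 percentage points lower from compound 3 to compound 4 (within the scatter)), while the (morpholin-4-yl)carbonyl group remains clearly separate from piperidin-1-yl (a number 32.9 percentage points lower from compound 1 to compound 4 (beyond the scatter)). No measurement is available that accounts for any of these differences.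

As far as these compounds go, it remains open whether the high reading of compound 1 goes with the carbonyl or with the morpholine ring, a separation that a (piperidin-1-yl)carbonyl group or a (morpholin-4-yl)methyl group on the same chain would provide. From the compounds shown here alone, how far the ring-size step extends is also open, and an azepan-1-yl group on the chain would test it.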